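The source may hold more compounds than are shown below. What is called first, only, known or untested is meant among the compounds shown, and "the series" means these compounds.

Compound 1 has the structure `Oc1ccccc1-c1cc(-c2ccccc2F)cc(-c2ccccc2O)n1`. In a functional assay on HCT-15 cells (Homo sapiens) for inhibition (on this read-out lower numbers stand for stronger inhibition and higher numbers for weaker inhibition), compound 1 gives > 50000 nM, which is a limit of the assay and not a number. Compound 2 has the structure `Oc1cccc(-c2cc(-c3ccccc3F)cc(-c3ccccc3O)n2)c1`, and compound 2 gives 8470 nM. Compound 3 has the structure `Oc1cccc(-c2cc(-c3ccccc3F)cc(-c3cccc(O)c3)n2)c1`, and compound 3 gives 5300 nM.

Among the numbers shown, compound 2 stands closest to compound 3, the step of a 1.6-fold lower number from compound 2 to compound 3 (0.20 log units; within the scatter) lying within the scatter, so neither can be ranked over the other. The remaining value is the limit of compound 1 (the limit of > 50000 nM in this assay, at which 1 of the 3 values shown sits). The step of an at least 5.9-fold lower number from compound 1 to compound 2 (0.77 log units; beyond the scatter) was beyond the scatter.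

Compound 4 has the structure `Oc1cccc(-c2cc(-c3cccc(C(F)(F)F)c3)cc(-c3ccccc3O)n2)c1` and differs from compound 2 by 3-(trifluoromethyl)phenyl in place of 2-fluorophenyl on an aromatic carbon. Neither measured step bears on this change: both steps concern the hydroxyphenyl groups, whereas here the 2-fluorophenyl group is exchanged. Within the data shown here, with no comparable step available, no shift beyond the scatter is expected in this assay, though the uncertainty is wide. Compound 4 is therefore estimated at 8000 nM, with a range from 2000 nM to 30000 nM. The expected step is a 1.1-fold lower number from compound 2 to compound 4 (0.02 log units; within the scatter).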

Compound 4, half-maximal inhibitory concentration: 6460 nM
Compound 4: middle estimate off by 1.2-fold (0.09 log units), on the high side; measured number inside the range.
By their numbers in this assay, from the lowest: compounds 3, 4 and 2 (each within the scatter of the next). At a limit, above all of these: compound 1.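

In this assay, the exchange of 2-fluorophenyl for 3-(trifluoromethyl)phenyl opposite the ring nitrogen gives a 1.3-fold lower number from compound 2 to compound 4 (0.12 log units; within the scatter) and so leaves the inhibition of compound 2 unchanged within the scatter. Among these compounds, the earlier steps concerned only the hydroxyphenyl groups, so this is the first reading at this position, and here a change of both the fluorine-bearing substituent and its place on the phenyl ring is accepted without a shift beyond the scatter. Nothing measured here gives a reason for this result.

Since the group and its place on the ring changed together, the two remain unseparated, and 3-fluorophenyl or 2-(trifluoromethyl)phenyl would be needed to tell them apart. From the compounds shown here alone, it also remains open how this position responds to a phenyl ring carrying an amine or a carboxylic acid, and whether 3-(trifluoromethyl)phenyl behaves the same way on the core of compound 3.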